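Extending the Carbamate Chain in a Gut-Hormone Receptor Series

The source may report more compounds than this note shows. Statements on the series, on what has been measured and on what is new or still open speak of the compounds shown alone.

Of the compounds shown here, three have been measured in a functional assay on CHO-K1 cells for agonist activity at Glucose-dependent insulinotropic receptor (Homo sapiens), read by a luciferase reporter, with a stated time of 5 h; on this read-out higher numbers stand for an effect only at larger amounts of compound and lower numbers for an effect already at smaller amounts. Compound 1 `CC(C)OC(=O)N1CCC(Oc2cccc3c2CCN3c2ccc(S(C)(=O)=O)cc2)CC1` gives 501 nM. Compound 2 `CC(C)OC(=O)N1CCC(Oc2ncnc3c2CCN3c2ccc(C#N)cc2F)CC1` gives 63.1 nM. Compound 3 `CCOC(=O)N1CCC(Oc2ncnc3c2CCN3c2ccc(S(C)(=O)=O)cc2F)CC1` gives 251 nM, which places compound 3 second highest of the three numbers; the gap to compound 1 falls inside the usual scatter of repeated measurements, while the gap to compound 2 lies beyond it.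

Compound 4 `COCCOC(=O)N1CCC(Oc2ncnc3c2CCN3c2ccc(S(C)(=O)=O)cc2F)CC1` is not yet measured. It differs from compound 3 in one place: methoxy in place of hydrogen on a saturated chain carbon, two bonds along the chain from an oxygen next to a carbonyl group. The carbamate chain is thus lengthened and gains an oxygen, while the core and the aryl group carrying the methylsulfonyl and fluorine remain unchanged.

Among the compounds with values here, no measured pair in this set shows what such a chain extension does, so the expectation rests on the overall picture: the step from compound 3 to compound 4 is expected to be small, a 1.0-fold lower number from compound 3 to compound 4 (0.00 log units; within the scatter), with no clear direction beyond the scatter. Compound 4 is therefore estimated at 250 nM, with a likely range from 100 nM to 630 nM.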

Compound 4, half-maximal effective concentration: 316 nM
Compound 4: the middle estimate sits 1.3-fold (0.10 log units) below what was measured; measured number inside the range.
By their numbers in this assay, from the lowest: compound 2; then compounds 3, 4 and 1 (each within the scatter of the next).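

Within the data shown here, replacing ethyl with 2-methoxyethyl on the carbamate gives the first comparison in this set of two compounds that differ in one place, and in this assay the change produces a 1.3-fold higher number from compound 3 to compound 4 (0.10 log units; within the scatter). This saturated chain can therefore carry methoxy in place of hydrogen, lengthening the chain and adding an oxygen, without a shift that stands out from the usual scatter of repeated measurements. Nothing available here accounts for this level result.

The compounds shown leave open whether this tolerance extends to a longer chain, or to a chain ending in an amine or a carboxylic acid. They also do not show whether the 2-methoxyethyl group would behave the same way alongside the nitrile-bearing aryl group of compound 2.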